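Benzyloxy in place of isobutoxy on a linked pair

The source may hold more compounds than are shown below. What is called first, only, known or untested is meant among the compounds shown, and "the series" means these compounds.

Compound 1 `O=c1c(/C=C/c2coc3ccccc3c2=O)coc2ccccc12` and compound 2 `CC(C)COc1cccc2occ(Cc3coc4ccccc4c3=O)c(=O)c12` share two of the same ring systems joined by a short linker. In a functional assay on NUGC-3 cells (Homo sapiens) for antiproliferative activity, read by XTT assay (on this read-out lower numbers stand for stronger inhibition and higher numbers for weaker inhibition), compound 1 gives > 10000 nM, which is a limit of the assay rather than a number. In this assay compound 2 likewise gives > 10000 nM, again a limit. Compound 2 therefore stands with compound 1 at the limit of > 10000 nM in this assay, at which 2 of the 2 values shown sit; no measured step exists between them, so no direction of change is shown.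

Compound 3 `O=c1c(Cc2coc3cccc(OCc4ccccc4)c3c2=O)coc2ccccc12` differs from compound 2 in one place: phenyl in place of isopropyl on a saturated chain carbon bound to an oxygen on an aromatic ring. With both measured compounds sitting at the limit, the step from compound 2 to compound 3 is expected to be none beyond the scatter, meaning a step that the limit leaves unreadable from compound 2 to compound 3. Compound 3 is estimated at 15000 nM, with a range from 4000 nM to 50000 nM.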

Compound 3, half-maximal inhibitory concentration: 7220 nM
For compound 3 the middle estimate is 2.1-fold (0.32 log units) above the measured one; measured number inside the range.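

Compound 3 is the only compound shown in this assay that gives a number rather than a limit, while the other two share that limit: the limit of > 10000 nM in this assay, at which 2 of the 3 values shown sit. Going by these compounds, replacing isobutoxy with benzyloxy at this position gives an at least 1.3-fold lower number from compound 2 to compound 3 (0.14 log units; that floor lies within the scatter), so the true size of the change remains unknown. The new information is that a phenyl on this saturated chain carbon is compatible with a measurable value, although this floor alone does not show that phenyl outperforms isopropyl.

On these data alone, whether a number for compound 2 would differ from that of compound 3 beyond the scatter remains open. Also open, as far as these compounds go, is how other groups on this chain carbon would read, such as a cyclohexyl ring, a pyridine ring or a phenyl carrying an amine.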